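Swapping a methylphenyl for a pyridyl on the alkyne linker

The compounds below may be only part of what the source reports. "The series", "measured", "known", "first", "only" and "open" are said of these compounds alone.

Measured so far:
compound 1, `CNC(=O)c1ccc(C#Cc2ccccc2)nc1`: 15000 nM
compound 2, `Cc1ccccc1C#Cc1ccc2c(n1)CCN(C(C)C)C2=O`: > 32000 nM

Of the compounds shown here, two have been tested in an assay on HEK293 cells for displacement of a labelled ligand from metabotropic glutamate receptor 5 (Homo sapiens), with a stated time of 2 h; on this read-out lower numbers stand for stronger inhibition and higher numbers for weaker inhibition. Compound 1, with a plain phenyl ring on the triple bond, gives 15000 nM, a weak result. Compound 2 carries a 2-methylphenyl group on the same kind of triple bond and a different core; in this assay compound 2 reaches only the limit of > 32000 nM, which is a boundary of what the assay can report and not a measured number. So compound 2 stands at the weak end of everything shown, at the limit of > 32000 nM in this assay, at which 1 of the 2 values shown sits.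

The next compound, compound 3, has the structure `CC(C)N1CCc2nc(C#Cc3cccnc3)ccc2C1=O`. It keeps the core of compound 2 and changes one thing: pyridin-3-yl in place of 2-methylphenyl on a triple-bonded carbon. For the measured compounds named here, no measured pair of compounds differs only in this way, so the size of the step is unknown from the data. Since compound 2 gives only a limit, a step in the stronger direction is expected, but its size is uncertain; the expected step is an at least 4.0-fold lower number from compound 2 to compound 3 (0.60 log units; beyond the scatter). Compound 3 is therefore estimated at 8000 nM, with a range from 1000 nM to 32000 nM.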

Compound 3, inhibition constant: 19600 nM
Compound 3: middle estimate off by 2.5-fold (0.39 log units), on the low side; low and high end bracket the measured number.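

In this assay compound 2 stands at > 32000 nM, and that is a limit of the assay, not a number. On the same core, compound 3 gives a measured value, which shows that changing the ring on this triple-bonded carbon can bring a compound of this series within what the assay can report, though the value for compound 3 is still a weak result. Going from 2-methylphenyl to pyridin-3-yl amounts to an at least 1.6-fold lower number from compound 2 to compound 3 (0.21 log units; that floor lies within the scatter); this figure is only a floor, so the true step may be larger, but the data cannot show that it goes beyond the usual scatter.

From the compounds shown here alone, it remains open whether the gain, if real, depends on the ring nitrogen of pyridin-3-yl or simply on losing the methyl group, and a plain phenyl on this same core would separate those two readings. Other rings on this triple-bonded carbon, such as pyridin-4-yl or a fluorophenyl, could also show whether any group on this core reaches clearly lower numbers, while compound 1 differs from compound 3 in more than one place and cannot settle the question.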